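Propanoyloxy to acetoxy on compound 1: working notes

The compounds below may be only part of what the source reports. "The series", "measured", "known", "first", "only" and "open" are said of these compounds alone.

Measured in a functional assay on A549 cells (Homo sapiens) for inhibition, read by MTT assay, with a stated time of 72 h; a lower number here means a stronger inhibitor, a higher number a weaker inhibitor:
- compound 1 `CCC(=O)O[C@@H](/C(C)=C/[C@@H](C)c1oc(CC)c(C)c(=O)c1C)[C@H](C)[C@@H](OC(=O)CC(C)C)[C@@H](C)c1oc([C@@H](C)[C@@H](O)CC)c(C)c(=O)c1C`: 12000 nM
- compound 2 `CCC(=O)[C@@H](C)c1oc([C@H](C)[C@@H]2O[C@](O)([C@@H](C)c3oc(CC)c(C)c(=O)c3C)[C@@H](C)[C@@H](O)[C@@H]2C)c(C)c(=O)c1C`: > 100000 nM, a limit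
- compound 3 `CCC(=O)[C@H](C)c1oc([C@H](C)[C@@H]2O[C@](O)([C@@H](C)c3oc(CC)c(C)c(=O)c3C)[C@@H](C)[C@@H](O)[C@@H]2C)c(C)c(=O)c1C`: > 100000 nM, a limit

In this assay, among the measured compounds shown here, compound 1 holds the only actual number, 12000 nM. Compound 2 and compound 3 stand at the limit of > 100000 nM in this assay, at which 2 of the 3 values shown sit.

Compound 4 `CCc1oc([C@H](C)/C=C(\C)[C@H](OC(C)=O)[C@H](C)[C@@H](OC(=O)CC(C)C)[C@@H](C)c2oc([C@@H](C)[C@@H](O)CC)c(C)c(=O)c2C)c(C)c(=O)c1C` departs from compound 1 by hydrogen in place of methyl on a saturated chain carbon bound to a carbonyl carbon, which reads as propanoyloxy to acetoxy. For the measured compounds named here, the one measured step is a step that the two limits leave unreadable from compound 2 to compound 3. It concerns the fact that compounds 2 and 3 differ only in the configuration as drawn and does not bear on this change. Going by the values given here, no measured step covers this change, so the expectation stays with compound 1 at 12000 nM, with no shift beyond the scatter expected in either direction. The estimated step is no change at the digits printed from compound 1 to compound 4 (within the scatter). Compound 4 is expected at 12000 nM, within an estimated range of 4000 nM to 36000 nM.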

Compound 4, half-maximal inhibitory concentration: 15000 nM
Compound 4: middle estimate off by 1.3-fold (0.10 log units), on the low side; measured number inside the range.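

In this assay, among the compounds shown here, the change of propanoyloxy to acetoxy gives a 1.3-fold higher number from compound 1 to compound 4 (0.10 log units; within the scatter), the first step that can be read, as the one earlier step lies between two limits and cannot be read. On a saturated chain carbon bound to a carbonyl carbon, hydrogen can thus stand in place of methyl with no shift beyond the scatter, and compound 4 keeps a measured number rather than a limit. Nothing measured here gives a cause for this outcome.

As far as these compounds go, how a longer chain such as butanoyloxy, a free hydroxy or an amine would read in place of propanoyloxy stays open. A single step at a single place also says nothing about changes elsewhere on the core of compound 1.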